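Pyridin-2-yl for Ethyl: An Expected Solubility Step

This account rests on a few compounds, and the source may have more. Where it says the series, first, only, none or still open, it means among the compounds named here.

Compound 1, `Cc1cc(C)n(-c2nc(C)c(-c3ccccc3)c(=O)[nH]2)n1`: 190000 nM
Compound 2, `Cc1cc(C)n(-c2nc(-c3ccc(S(C)(=O)=O)cc3)cc(=O)[nH]2)n1`: 8000 nM
Compound 3, `CCNc1cc(C)nn1-c1nc(C(F)(F)F)cc(=O)[nH]1`: 85000 nM

In a physicochemical assay for solubility, at pH 7.4 (on this read-out lower numbers stand for lower solubility and higher numbers for higher solubility), compound 3 gives 85000 nM, the second highest of the three numbers. Compound 1 gives 190000 nM, a higher number by a margin beyond the scatter, and compound 2 gives 8000 nM, a lower number by a margin well beyond the scatter. For the measured compounds named here, no step between two measured compounds that differ in a single place is available, so the move to compound 4 has to be judged from these three values and the structural change alone.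

Compound 4, `Cc1cc(Nc2ccccn2)n(-c2nc(C(F)(F)F)cc(=O)[nH]2)n1`, differs from compound 3 in one place: pyridin-2-yl in place of ethyl on a nitrogen on an aromatic ring. Among the measured compounds, compound 1 and compound 2 both contain an additional six-membered aromatic ring and sit at the highest and the lowest number of the set, so the three values offer no clear pattern for this kind of addition. The added ring carries one hydrogen-bond acceptor, but the measured set gives nothing that would tie such a count to a direction. On balance the step is expected to go down, by a margin beyond the scatter, as a 4.3-fold lower number from compound 3 to compound 4 (0.63 log units; beyond the scatter). Compound 4 is therefore estimated at 20000 nM, within a range from 5000 nM to 80000 nM.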

Compound 4, solubility: 25000 nM
Compound 4: the middle estimate sits 1.3-fold (0.10 log units) below what was measured, and the stated range covers the measured number.
By their numbers in this assay, from the lowest: compound 2; then compound 4; then compound 3; then compound 1.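

In this assay, pyridin-2-yl in place of ethyl on a nitrogen on an aromatic ring gives a 3.4-fold lower number from compound 3 to compound 4 (0.53 log units; beyond the scatter), a modest step that lies beyond the scatter. For the compounds shown here, none of the earlier compounds formed a pair differing in a single place, so this is the first direction read at this position, and it is downward for this change. Compound 4 still reads 25000 nM with the added six-membered aromatic ring in place, and nothing at hand bears on the reason for the step.

A single step changes the ring, the heavy-atom count and the hydrogen-bond acceptor count together, so it leaves open which of these goes with the lower number, and a phenyl, a pyridin-3-yl or a butyl chain on the same nitrogen would separate them. It also leaves open whether the ethylamino to (pyridin-2-yl)amino change would move the number the same way and by a similar size on a core carrying a methyl or a phenyl group instead of the trifluoromethyl group of compound 3.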